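A Methoxy Added to the Shared Core

This account rests on a few compounds, and the source may have more. Where it says the series, first, only, none or still open, it means among the compounds named here.

Of the compounds shown here, three built on one shared core have been tested in a functional assay on MCF7 cells (Homo sapiens) for cytotoxicity, read by sulforhodamine B assay, with a stated time of 48 h; a higher number here means a weaker inhibitor of growth, a lower number a stronger inhibitor of growth. Compound 1 `COc1ccc2[nH]cc(C(=O)/C(C#N)=C/C=C(\Cl)c3ccc(OC)c(OC)c3)c2c1` gives 44900 nM. Compound 2 `COc1ccc2[nH]cc(C(=O)/C(C#N)=C/C=C(\Cl)c3ccc(Br)cc3)c2c1` gives 79900 nM. Compound 3 `COc1ccc(/C(Cl)=C/C=C(\C#N)C(=O)c2c[nH]c3ccccc23)cc1` gives 47300 nM. Compound 3 thus stands second highest of the three numbers, and its gaps to compound 1 and to compound 2 both lie within the usual scatter of repeated measurements, so on these data the three compounds cannot be told apart.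

Compound 4 `COc1ccc(/C(Cl)=C/C=C(\C#N)C(=O)c2c[nH]c3ccc(OC)cc23)cc1` is reached from compound 3 by a single change: methoxy in place of hydrogen on an aromatic carbon. Among the compounds with values here, no measured step makes exactly this change. Within the data shown here, the one step that has been measured, a 1.8-fold higher number from compound 1 to compound 2 (0.25 log units; within the scatter), concerns a different part of the molecule and stays within the scatter. Compound 1 and compound 2 already carry this methoxy group, and their numbers sit close to that of compound 3, which suggests that the group by itself does not move the read-out far. The expected step of a 1.0-fold lower number from compound 3 to compound 4 (0.00 log units; within the scatter) is therefore none beyond the scatter. Compound 4 is estimated at 47000 nM, with a range from 20000 nM to 110000 nM.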

Compound 4, concentration for 50% growth inhibition: 87100 nM
Compound 4: middle estimate off by 1.9-fold (0.27 log units), on the low side; low and high end bracket the measured number.
By their numbers in this assay, from the lowest: compounds 1, 3, 2 and 4 (each within the scatter of the next).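

In this assay, within the data shown here, the first direct reading of methoxy in place of hydrogen on this aromatic carbon of the fused two-ring system is a 1.8-fold higher number from compound 3 to compound 4 (0.27 log units; within the scatter) and so, at this position, the added group gives no step that can be told apart from repeat-measurement noise. Among these compounds, two changes on the phenyl ring at the other end of the chain also stay inside that noise: methoxy in place of bromo gives a 1.1-fold higher number from compound 2 to compound 4 (0.04 log units; within the scatter) and hydrogen in place of methoxy gives a 1.9-fold higher number from compound 1 to compound 4 (0.29 log units; within the scatter) so all of the single changes measured so far leave these compounds unresolved in this read-out. No measurement is available that would explain these numbers.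

The compounds shown leave open whether a different group on this same aromatic carbon, such as an amine, a carboxylic acid or a longer chain, would produce a step beyond the scatter. Among the compounds shown here, also open is whether methoxy in place of hydrogen here would read the same with another group on the phenyl ring, since compound 3 and compound 4 are the only pair that isolates this change.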